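The source may hold more compounds than are shown below. What is called first, only, known or untested is meant among the compounds shown, and "the series" means these compounds.

Measured in a functional assay on PC-3 cells (Homo sapiens) for cytotoxicity, read by MTT assay, with a stated time of 72 h; on this read-out higher numbers stand for weaker inhibition and lower numbers for stronger inhibition:
- compound 1 `COc1cc2ncnc(Nc3ccc(F)c(Cl)c3)c2cc1NC(=O)N/N=C/c1ccc(F)cc1`: 36500 nM
- compound 2 `COc1cc2ncnc(Nc3ccc(F)c(Cl)c3)c2cc1NC(=O)N/N=C/c1ccc(C#N)cc1`: 36500 nM

Going by the values given here, compound 2 stands at 36500 nM in this assay, level with the only other measured compound. Compound 3 `COc1cc2ncnc(Nc3ccc(F)c(Cl)c3)c2cc1NC(=O)N/N=C/c1ccc(F)cc1Cl` carries 2-chloro-4-fluorophenyl in place of 4-cyanophenyl on a carbon with a double bond to nitrogen.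

Among the compounds with values here, only one measured step bears on this change. Cyano in place of fluoro on an aromatic carbon gave no change at the digits printed from compound 1 to compound 2 (within the scatter), so a swap of substituents on this aromatic ring has not yet moved the value in this assay. Within the data shown here, that is thin support, and no measured compound carries 2-chloro-4-fluorophenyl. No shift beyond the scatter is expected, in either direction, and the range is kept wide.

The expected step is a 1.0-fold lower number from compound 2 to compound 3 (0.02 log units; within the scatter).

Compound 3 is estimated at 35000 nM, with an expected range of 15000 nM to 70000 nM.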

Compound 3, half-maximal inhibitory concentration: 25700 nM
Estimate against measurement, compound 3: 1.4-fold (0.13 log units) above, and the stated range covers the measured number.
By their numbers in this assay, from the lowest: compounds 3, 1 and 2 (each within the scatter of the next).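

Notes on the group on the carbon with a double bond to nitrogen: in this assay, the first change to alter the substitution pattern rather than swap one substituent for another still stays within the scatter (a 1.4-fold lower number from compound 1 to compound 3 (0.15 log units; within the scatter)). Replacing 4-cyanophenyl with 2-chloro-4-fluorophenyl, which differs from it in two substituents, reads the same way (a 1.4-fold lower number from compound 2 to compound 3 (0.15 log units; within the scatter)), so the three aryl groups shown do not separate at this position. No measurement on hand bears on why these values sit where they do.

Still open, going by these compounds, is whether an amine or a carboxylic acid on this ring, or a longer chain in place of the ring, would separate from these three in this assay. The compounds shown also leave open how much of the level they share rests on the shared core, which stays the same throughout.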